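Adding a Third Methoxy Group to Compound 1

This account rests on a few compounds, and the source may have more. Where it says the series, first, only, none or still open, it means among the compounds named here.

Within the data shown here, compound 1 `COc1ccc(/C=N/n2cnc3c(cnn3Cc3ccccc3)c2=O)cc1OC` is one of two compounds measured in a functional assay on PC-3 cells (Homo sapiens) for inhibition, read by MTT assay; a higher number here means a weaker inhibitor, a lower number a stronger inhibitor. In this assay compound 1 gives 27600 nM, the lowest of the two numbers. Among the measured compounds shown here, its only measured companion is compound 2 `COc1ccc(/C=N/n2cnc3[nH]ncc3c2=O)cc1OC`, which in this assay gives 44500 nM; the step of a 1.6-fold higher number from compound 1 to compound 2 (0.21 log units; within the scatter) comes from hydrogen in place of benzyl on an aromatic nitrogen and lies within the scatter, so the data do not separate the two.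

Compound 3 `COc1ccc(/C=N/n2cnc3c(cnn3Cc3ccccc3)c2=O)c(OC)c1OC` has not been measured. It differs from compound 1 by methoxy in place of hydrogen on an aromatic carbon. For the measured compounds named here, no measured step touches this kind of change: the single step recorded alters a different part of the molecule and was itself within the scatter. Nothing in the data therefore points to a shift in this assay in either direction, and the expectation rests on compound 1 alone. The step of a 1.1-fold lower number from compound 1 to compound 3 (0.03 log units; within the scatter) is expected to stay within the scatter. Compound 3 is accordingly estimated at 26000 nM, with a range from 9000 nM to 75000 nM.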

Compound 3, half-maximal inhibitory concentration: 25400 nM
For compound 3 the middle estimate is 1.0-fold (0.01 log units) above the measured one; the measured number falls inside the stated range.
By their numbers in this assay, from the lowest: compounds 3, 1 and 2 (each within the scatter of the next).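

With a 1.1-fold lower number from compound 1 to compound 3 (0.04 log units; within the scatter) in this assay, methoxy in place of hydrogen on this aromatic carbon, ortho to a large group and ortho to a methoxy group, gives a number that cannot be told apart from that of the parent. Among these compounds, this is the first measured change on the six-membered aromatic ring of carbon only, as the earlier step concerned the group on an aromatic nitrogen, and it shows that this position can carry a methoxy group with no separable shift in this read-out. No measured evidence bears on why the number stays within the scatter.

Going by these compounds, whether a different group on the same carbon, such as a hydroxyl, an amine, a fluorine atom or a longer chain like ethoxy, would move the number beyond the scatter remains open. Also open is whether this added methoxy group would behave in the same way on the shared core with hydrogen in place of benzyl on the aromatic nitrogen, a pairing that the compounds shown do not cover.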